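Propargyl ester change carried onto a second ester

The source may hold more compounds than are shown below. What is called first, only, known or untested is meant among the compounds shown, and "the series" means these compounds.

The study began with compound 1 `CCOC(=O)CC1C(C(=O)OCC)=C(N)Oc2ccc(-c3cccc(NC)c3)cc21`, which in a functional assay on HL-60 cells (Homo sapiens) for cytotoxicity, read by CellTiter-Blue, with a stated time of 48 h (on this read-out higher numbers stand for weaker inhibition and lower numbers for stronger inhibition), gives 7450 nM. Compound 2 `C#CCOC(=O)CC1C(C(=O)OCC)=C(N)Oc2ccc(-c3cccc(NC)c3)cc21` carries the change ethynyl in place of methyl on a saturated chain carbon bound to an oxygen next to a carbonyl group and gives 7130 nM, so that a 1.0-fold lower number from compound 1 to compound 2 (0.02 log units; within the scatter). Compound 3 `C#CCOC(=O)CC1C(C(=O)OCC)=C(N)Oc2ccc(-c3cccc(NCC)c3)cc21` gives 17200 nM, and a 2.4-fold higher number from compound 2 to compound 3 (0.38 log units; beyond the scatter). The difference between the core of compound 1 and the core of compound 3 is not broken down here. The unmeasured compound 4 `C#CCOC(=O)CC1C(C(=O)OCC#C)=C(N)Oc2ccc(-c3cccc(NCC)c3)cc21` differs from compound 3 by ethynyl in place of methyl on a saturated chain carbon bound to an oxygen next to a carbonyl group, which is the same change seen from compound 1 to compound 2 and in the same place. Because that earlier step was a 1.0-fold lower number from compound 1 to compound 2 (0.02 log units; within the scatter), the corresponding step is expected to be small, and compound 4 is estimated to show a 1.0-fold lower number from compound 3 to compound 4 (0.01 log units; within the scatter) in this assay. Within the data shown here, on this basis compound 4 is expected to give about 17000 nM, within a range from 8000 nM to 36000 nM, with the width resting on only one earlier example of this change.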

Compound 4, half-maximal inhibitory concentration: 1860 nM
Beside the measured number, compound 4's estimate is 9.1-fold (0.96 log units) above it; measured number outside the range, below it.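

The last change brought a 9.2-fold lower number from compound 3 to compound 4 (0.97 log units; beyond the scatter), so the ethyl to propargyl change did not keep its size from one core to the other in this assay: the same change on two cores in this assay, a 1.0-fold lower number (0.02 log units; within the scatter) from compound 1 to compound 2 and a 9.2-fold lower number (0.97 log units; beyond the scatter) from compound 3 to compound 4, 8.9-fold (0.95 log units) apart, beyond the scatter of two such steps The two steps also fall on different esters of the molecule, and the second was taken with the other ester already propargyl and with a longer chain on the nitrogen of the aromatic ring, so the gap cannot be assigned to any one of these differences. Among these compounds, with a single example on each core, this shows only that the earlier step did not predict the later one, and it gives neither a general rule for the series nor a cause.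

The compounds shown leave open whether the remaining ethyl ester of compound 2 would respond to the same change as that of compound 3 did. They also leave open how a carboxylic acid or an amide in place of either ester, or a propyl chain on the nitrogen, would behave.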